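Extending the amide from benzoyl to cinnamoyl on a shared core

A few compounds are considered here, and "the series" means these few. Any claim that something is new, unique, unknown or untested is made for them only; others in the source may bear on it.

Compound 1 `CN(C)CCNc1cc2c(cn1)cc(NC(=O)c1ccccc1)c(=O)n2C` was tested in a functional assay on MCF7 cells (Homo sapiens) for antiproliferative activity, read by MTT assay, with a stated time of 48 h (on this read-out higher numbers stand for weaker inhibition and lower numbers for stronger inhibition), and gives 35100 nM, the highest of the two numbers recorded so far. Among the measured compounds shown here, its nearest neighbour is compound 2 `CN(C)CCNc1cc2c(cn1)cc(NC(=O)c1cccc(-c3ccccc3)c1)c(=O)n2C`, which gives 1930 nM; the single change between them, phenyl in place of hydrogen on an aromatic carbon, produced an 18-fold lower number from compound 1 to compound 2 (1.26 log units; beyond the scatter). Compound 3 `CN(C)CCNc1cc2c(cn1)cc(NC(=O)/C=C/c1ccccc1)c(=O)n2C`, not yet measured, differs from compound 1 by 2-phenylethenyl in place of phenyl on a carbonyl carbon. For the measured compounds named here, no measured step covers this exact change; only the step from compound 1 to compound 2 bears on it, and it shows that enlarging the group on the amide carbonyl side of the core can move the number strongly. A smaller gain is therefore expected here, with a 3.5-fold lower number from compound 1 to compound 3 (0.55 log units; beyond the scatter). Compound 3 is estimated at 10000 nM, with a range from 3000 nM to 35000 nM.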

Compound 3, half-maximal inhibitory concentration: 27400 nM
For compound 3 the middle estimate is 2.7-fold (0.44 log units) below the measured one, within the range that was stated.
By their numbers in this assay, from the lowest: compound 2; then compounds 3 and 1 (each within the scatter of the next).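

In this assay, putting 2-phenylethenyl in place of phenyl on the carbonyl carbon, which brings in a double bond outside aromatic rings and a larger group, gives a 1.3-fold lower number from compound 1 to compound 3 (0.11 log units; within the scatter) and so leaves the number unchanged within the scatter. A larger group on this side of the amide therefore does not by itself lower the number, since the gain seen with an 18-fold lower number from compound 1 to compound 2 (1.26 log units; beyond the scatter) came from phenyl in place of hydrogen on an aromatic carbon and does not appear with this change. Nothing measured here accounts for the difference between these two changes.

On these data alone, it remains open whether a 2-phenylethyl group on the same carbonyl carbon would match 2-phenylethenyl, which would show whether the double bond matters. Also open, as far as these compounds go, is whether groups such as methoxy or an amine on that aromatic carbon would lower the number as phenyl does.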